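The compounds below may be only part of what the source reports. "The series", "measured", "known", "first", "only" and "open" are said of these compounds alone.

Working notes on the series built on the core of compound 1 `COC(=O)c1cccc(-c2cnc(Nc3ccc(F)cc3)o2)c1`.

In an ADME assay on microsomes from liver (Homo sapiens) for metabolic stability, read by LC-MS, using NADPH (a higher number here means that the compound lasts longer, a lower number that the compound disappears faster), compound 1 gives < 0.0167 h, which is a limit of the assay and not a number (the limit of < 0.0167 h in this assay, at which 1 of the 3 values shown sits). Compound 2 `Cc1noc(-c2cccc(-c3cnc(Nc4ccc(F)cc4)o3)c2)n1` gives 0.575 h in this assay. Compound 3 `NCc1cccc(-c2cnc(Nc3ccc(F)cc3)o2)c1` gives 0.818 h in this assay; this is the highest of the two numbers shown, with compound 2 sitting within the scatter of it. The steps of an at least 34-fold higher number from compound 1 to compound 2 (1.53 log units; beyond the scatter) and an at least 48-fold higher number from compound 1 to compound 3 (1.69 log units; beyond the scatter) are both large, whereas the step of a 1.4-fold higher number from compound 2 to compound 3 (0.15 log units; within the scatter) is not.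

Compound 4 `Nc1cccc(-c2cnc(Nc3ccc(F)cc3)o2)c1` has not yet been measured in this assay. It differs from compound 3 by amino in place of aminomethyl on an aromatic carbon. Going by the values given here, no measured step exchanges these two groups directly; the only steps that touch compound 3 are the large one from compound 1 and the small one from compound 2, and the change to compound 4 does not revisit the methoxycarbonyl of compound 1. A step of about a 1.2-fold lower number from compound 3 to compound 4 (0.07 log units; within the scatter) is therefore expected, not beyond the scatter in either direction. Compound 4 is estimated at 0.7 h in this assay, with a range from 0.3 h to 1.8 h.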

Compound 4, half-life: 0.0467 h
Compound 4: the middle estimate sits 15-fold (1.18 log units) above what was measured, outside the stated range (below it).
By their numbers in this assay, from the lowest: compound 4; then compounds 2 and 3 (each within the scatter of the next). At a limit, below all of these: compound 1.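

At this place, on an aromatic carbon of the six-membered ring and meta to a large group, the two earlier replacements of methoxycarbonyl stood within the scatter of each other, whereas amino separates clearly from both in this assay, with an 18-fold lower number from compound 3 to compound 4 (1.24 log units; beyond the scatter) and a 12-fold lower number from compound 2 to compound 4 (1.09 log units; beyond the scatter). Amino and aminomethyl have the same hydrogen-bond donor and acceptor counts and neither carries a net charge, so those counts do not separate a large step from a small one here, and losing methoxycarbonyl does not by itself bring the number up to the level of the other two replacements: the step is an at least 2.7-fold higher number from compound 1 to compound 4 (0.44 log units; beyond the scatter). That step has only a lower bound, as the value of compound 1 is a limit and not a number: the limit of < 0.0167 h in this assay, at which 1 of the 4 values shown sits.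

What the values shown cannot tell is which part of any of these molecules is lost in this assay, or why the two groups differ. On these data alone, it also remains open whether a longer chain such as aminoethyl, or a hydroxyl or acetamide group at this place, would fall with compound 3 or with compound 4.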